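The source may hold more compounds than are shown below. What is called first, only, known or untested is meant among the compounds shown, and "the series" means these compounds.

Working notes on the series. In a functional assay on LoVo cells (Homo sapiens) for cytotoxicity, read by colorimetric assay and MTT assay (on this read-out higher numbers stand for weaker inhibition and lower numbers for stronger inhibition), compound 1 (`COc1cccc2cc(-c3ccccc3)c(O)nc12`) gives 10000 nM. Compound 2 (`COc1cc(OC)c2cc(-c3ccccc3)c(O)nc2c1`) gives 10000 nM in this assay. Compound 3 (`COc1ccc(-c2cc3c(OC)cc(OC)cc3n(CCCC#N)c2=O)cc1`) gives 10000 nM in this assay, which places it level with compounds 1 and 2, all three within the scatter of one another.

The next compound to be read is compound 4 (`COc1ccc(-c2cc3c(OC)cc(OC)cc3n(CCC(=O)OCc3ccccc3)c2=O)cc1`). It differs from compound 3 in one place: benzyloxycarbonyl in place of cyanomethyl on a saturated chain carbon, two bonds along the chain from an aromatic nitrogen. Cut one bond further out, the same difference reads 2-cyanoethyl to (benzyloxycarbonyl)methyl.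

Among the measured compounds shown here, no two measured compounds differ in only one place, so the series offers no measured step to scale this change against. For the measured compounds named here, the only guide is the level shared so far, with compound 3 at 10000 nM. No step beyond the scatter is therefore expected in this assay, although stronger inhibition is left open in the range. The expected step is a 1.3-fold lower number from compound 3 to compound 4 (0.10 log units; within the scatter), which would stay within the scatter. For compound 4 the estimated value is 8000 nM, with an expected range of 3000 nM to 14000 nM.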

Compound 4, half-maximal inhibitory concentration: 10000 nM
Compound 4: middle estimate off by 1.3-fold (0.10 log units), on the low side; measured number inside the range.
By their numbers in this assay, from the lowest: compounds 1, 2, 3 and 4 (each within the scatter of the next).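

In this assay, among the compounds shown here, benzyloxycarbonyl in place of cyanomethyl on a saturated chain carbon, two bonds along the chain from an aromatic nitrogen, gives no change at the digits printed from compound 3 to compound 4 (within the scatter), the first step that can be read between compounds differing in one place. At this position, a group of 10 heavy atoms carrying a six-membered aromatic ring can therefore replace one of 3 heavy atoms with a triple bond, with no step beyond the scatter in this read-out. Nothing available bears on why the read-out stays level across this change.

From the compounds shown here alone, whether a carboxylic acid, an amine or a longer chain at this position would move the number away from the level shared by compound 3 and compound 4 remains open. For the compounds shown here, also open is whether any group here can bring stronger inhibition on the core of compound 3, since this single step shows only one exchange that leaves the number level.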